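Lengthening the Amine Substituent on a Second Scaffold

The compounds below may be only part of what the source reports. "The series", "measured", "known", "first", "only" and "open" are said of these compounds alone.

Compound 1 `C=C(c1ccc(OC)cc1NC(=O)CNC)c1ccc(OC)c2c1OC(C)(C)C=C2` and compound 2 `C=C(c1cc(OC)c(OC)c(OC)c1)c1ccc(OC)cc1NC(=O)CNC` share a side chain ending in a methylamino group but differ in the aromatic part that carries the vinyl group; that difference between the two cores is not broken down here. In a functional assay on HeLa cells (Homo sapiens) for antiproliferative activity, read by MTT assay, with a stated time of 48 h (a higher number here means a weaker inhibitor, a lower number a stronger inhibitor), compound 1 gives 310 nM, while compound 2 gives 140 nM, the lowest number of the three measured compounds. Compound 3 `C=C(c1ccc(OC)cc1NC(=O)CNCC)c1ccc(OC)c2c1OC(C)(C)C=C2` is compound 1 with methyl in place of hydrogen on a saturated chain carbon bound to an amine nitrogen. This change costs activity: a 3.5-fold higher number from compound 1 to compound 3 (0.55 log units; beyond the scatter), and compound 3 gives 1090 nM in this assay.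

Compound 4 `C=C(c1cc(OC)c(OC)c(OC)c1)c1ccc(OC)cc1NC(=O)CNCC` applies the same change to compound 2, namely (methyl in place of hydrogen on a saturated chain carbon bound to an amine nitrogen), at the same kind of position. The expectation for compound 4 rests on a single precedent, the step of a 3.5-fold higher number from compound 1 to compound 3 (0.55 log units; beyond the scatter), so it carries real uncertainty. Still, the step from compound 2 to compound 4 is expected to be a 3.4-fold higher number from compound 2 to compound 4 (0.54 log units; beyond the scatter). Compound 4 is therefore estimated at 480 nM in this assay, with a plausible range from 200 nM to 1200 nM.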

Compound 4, half-maximal inhibitory concentration: 430 nM
For compound 4 the middle estimate is 1.1-fold (0.05 log units) above the measured one, within the range that was stated.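

Replacing methylamino with ethylamino on the core of compound 2 weakens activity in this assay, giving a 3.1-fold higher number from compound 2 to compound 4 (0.49 log units; beyond the scatter). Set beside the earlier step, the change costs about the same on both cores: the same change on two cores in this assay, a 3.5-fold higher number (0.55 log units; beyond the scatter) from compound 1 to compound 3 and a 3.1-fold higher number (0.49 log units; beyond the scatter) from compound 2 to compound 4, 1.1-fold (0.06 log units) apart, within the scatter of two such steps. For these two pairs, then, the change carries from one core to the other with its size intact, but two pairs in a single cell assay cannot show that it would do so on any further core, and they do not explain why activity falls.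

The compounds shown stop at methylamino and ethylamino, so it remains open how a longer chain such as propyl, a branched group such as isopropyl, or a plain primary amine would behave on either core. Going by these compounds, it also remains open whether the same loss would appear in cell lines other than HeLa.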